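Moving the carboxylic acid around the ring of compound 2

A few compounds are considered here, and "the series" means these few. Any claim that something is new, unique, unknown or untested is made for them only; others in the source may bear on it.

Compound 2 `Cc1c(OC[C@@H](C)COc2ccc(Cl)c(C(=O)O)c2)ccc(C(=O)CC(C)(C)C)c1O` has the higher of the two values available in an assay for positive allosteric modulation of metabotropic glutamate receptor 2 (Rattus norvegicus); a lower number here means that less compound is needed, a higher number that more compound is needed for the effect: compound 2 gives 377 nM, while compound 1 `Cc1c(OCCCCOc2ccc(Cl)c(C(=O)O)c2)ccc(C(=O)CC(C)(C)C)c1O` gives 87 nM, a gap that lies beyond the usual scatter. Compound 3 `Cc1c(OC[C@@H](C)COc2ccc(C(=O)O)cc2Cl)ccc(C(=O)CC(C)(C)C)c1O` keeps every atom of compound 2 and differs only in 4-carboxy-2-chlorophenyl in place of 3-carboxy-4-chlorophenyl on an oxygen on a saturated carbon. Among the measured compounds shown here, no measured pair shows what this rearrangement does, so the expectation rests on judgment alone. For compound 3 a modest step towards a higher number is expected, a 1.6-fold higher number from compound 2 to compound 3 (0.20 log units; within the scatter), and its value is estimated at 600 nM, within a range from 150 nM to 2500 nM.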

Compound 3, half-maximal effective concentration: 477 nM
Beside the measured number, compound 3's estimate is 1.3-fold (0.10 log units) above it; low and high end bracket the measured number.
By their numbers in this assay, from the lowest: compound 1; then compounds 2 and 3 (each within the scatter of the next).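

Putting 4-carboxy-2-chlorophenyl in place of 3-carboxy-4-chlorophenyl gives a 1.3-fold higher number from compound 2 to compound 3 (0.10 log units; within the scatter) in this assay, so these two arrangements of the same atoms cannot be told apart on the chain of compound 2. Among the compounds shown here, this is the first reading of such a rearrangement. No available evidence explains the result.

As far as these compounds go, whether the rearrangement would read the same way on the chain of compound 1 remains open. Also open, from the compounds shown here alone, is how a fluorine in place of the chlorine, or a methyl ester in place of the carboxylic acid, would behave on this ring.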